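The source may hold more compounds than are shown below. What is called first, only, known or untested is meant among the compounds shown, and "the series" means these compounds.

Measured so far: compound 1 `COc1ccc(-c2ccc(OCc3cc(C(=O)NS(=O)(=O)c4ccccc4)oc3C)cc2)c(C)c1` gives 21 nM; compound 2 `COc1ccc(-c2ccc(OCc3cc(C(=O)NS(=O)(=O)c4ccccc4)oc3C)cc2)cc1` gives 5 nM; compound 3 `Cc1oc(C(=O)O)cc1COc1ccc(-c2ccccc2)cc1` gives 420 nM.

All three were run in an assay on cells for displacement of a labelled ligand from prostaglandin E2 receptor EP4 subtype (Homo sapiens), read by scintillation counting; on this read-out higher numbers stand for weaker inhibition and lower numbers for stronger inhibition. Compound 2 differs from compound 1 by hydrogen in place of methyl on an aromatic carbon, and that single change gave a 4.2-fold lower number from compound 1 to compound 2 (0.62 log units; beyond the scatter). Going by the values given here, compound 3 stands on a different core from compound 1; the difference between the two cores is not broken down here, and the values show only that compound 3 gives the highest number of the three.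

Compound 4 `O=C(O)c1cc(COc2ccc(-c3ccccc3)cc2)co1` is not yet measured. It differs from compound 3 by hydrogen in place of methyl on an aromatic carbon. This is the same kind of change as that from compound 1 to compound 2, but the place is not the same: in compound 1 the methyl sits on a six-membered aromatic ring of carbon only, ortho to a large group and meta to a methoxy group, whereas in compound 3 it sits on a five-membered aromatic ring with 1 oxygen, next to the ring oxygen and two ring bonds from the ring atom that bears a carboxy group. Among the compounds with values here, with only one earlier instance, on another ring and another core, the step from compound 3 to compound 4 in this assay is expected to be small and of uncertain direction, a 1.2-fold higher number from compound 3 to compound 4 (0.08 log units; within the scatter). The expectation for compound 4 rests on compound 3 giving 420 nM and on the earlier step being only modest. Compound 4 is thus estimated at 500 nM, expected to lie between 150 nM and 1600 nM.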

Compound 4, inhibition constant: 2000 nM
Compound 4: the middle estimate sits 4.0-fold (0.60 log units) below what was measured; measured number outside the range, above it.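

In this assay, hydrogen in place of methyl on the five-membered aromatic ring with 1 oxygen gave a 4.8-fold higher number from compound 3 to compound 4 (0.68 log units; beyond the scatter), so on this core the methyl goes with the lower number. The same kind of change does not carry over in direction from one core to the other: the same change on two cores in this assay, a 4.2-fold lower number (0.62 log units; beyond the scatter) from compound 1 to compound 2 and a 4.8-fold higher number (0.68 log units; beyond the scatter) from compound 3 to compound 4, 20-fold (1.30 log units) apart, beyond the scatter of two such steps The two pairs differ both in core and in the ring that carries the methyl, and the data cannot separate these two differences; each direction also rests on a single pair.

Open, going by these compounds, is what hydrogen in place of the methyl on the five-membered aromatic ring with 1 oxygen would do on the core of compound 2, which bears a methyl on that ring too, and this would show whether the step from compound 3 holds on another core at the same place. Also open, on these data alone, is whether an ethyl group or a chlorine atom at that place would give a number nearer to compound 3 or to compound 4.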